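Replacing Chloro with Cyano in Compound 3

The source may report more compounds than this note shows. Statements on the series, on what has been measured and on what is new or still open speak of the compounds shown alone.

Compound 1 `Cc1ccccc1-n1cc(-c2ccc(/C=C3\C(=O)Nc4ccccc43)cc2)nn1` gives 8710 nM
Compound 2 `Cc1ccccc1-n1cc(-c2ccc(C=C3C(=O)Nc4ccc(F)cc43)cc2)nn1` gives 5870 nM
Compound 3 `O=C1Nc2ccc(F)cc2C1=Cc1ccc(-c2cn(-c3ccc(Cl)cc3)nn2)cc1` gives 11200 nM

In a functional assay on HT-29 cells (Homo sapiens) for inhibition, read by CCK-8 assay, with a stated time of 24 h (on this read-out higher numbers stand for weaker inhibition and lower numbers for stronger inhibition), compound 3 stands at 11200 nM, within the scatter of both compound 1 and compound 2, so these numbers set no order among the three. The change to compound 4 `N#Cc1ccc(-n2cc(-c3ccc(C=C4C(=O)Nc5ccc(F)cc54)cc3)nn2)cc1` is cyano in place of chloro on an aromatic carbon, para to a large group. Among the compounds with values here, only one measured step touches the group on the aromatic nitrogen: a 1.9-fold higher number from compound 2 to compound 3 (0.28 log units; within the scatter). Within the data shown here, no measured step exchanges chloro for cyano, so the data offer no ground for a shift. In this assay the expected outcome is a 1.2-fold lower number from compound 3 to compound 4 (0.09 log units; within the scatter), which is no step beyond the scatter. Compound 4 is estimated at 9000 nM, with an expected range from 4000 nM to 20000 nM.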

Compound 4, half-maximal inhibitory concentration: 20000 nM
Compound 4: the middle estimate sits 2.2-fold (0.35 log units) below what was measured, within the range that was stated.
By their numbers in this assay, from the lowest: compounds 2, 1, 3 and 4 (each within the scatter of the next, the first and the last beyond it).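

In this assay the exchange of chloro for cyano on the aromatic carbon (a 1.8-fold higher number from compound 3 to compound 4 (0.25 log units; within the scatter)) does not separate compound 4 from compound 3. Changing the group on the aromatic nitrogen from 2-methylphenyl to 4-cyanophenyl does give a modest step beyond the scatter (a 3.4-fold higher number from compound 2 to compound 4 (0.53 log units; beyond the scatter)), which the step to 4-chlorophenyl had not. No evidence is available to explain this result.

The compounds shown leave open how an amine or a carboxylic acid in place of cyano would read in this assay. They also leave open whether 4-cyanophenyl would give a similar step on the core of compound 1.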